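Tetrabromo benzotriazole alcohols: shortening the hydroxyalkyl chain

This account rests on a few compounds, and the source may have more. Where it says the series, first, only, none or still open, it means among the compounds named here.

Measured so far:
- compound 1 `COc1cccc(C(O)CCn2nc3c(Br)c(Br)c(Br)c(Br)c3n2)c1`: 106%
- compound 2 `C[C@@H](O)CCn1nc2c(Br)c(Br)c(Br)c(Br)c2n1`: 81%
- compound 3 `OC(CCn1nc2c(Br)c(Br)c(Br)c(Br)c2n1)c1ccc(Cl)cc1`: 106%

In a functional assay on CCRF-CEM cells (Homo sapiens) for antiproliferative activity, read by MTT assay, with a stated time of 24 h, tested at 25 uM (a higher number here means a weaker effect of the compound at the concentration tested, a lower number a stronger effect), compound 2 gives the lowest of the three numbers, and its two neighbours, compound 1 and compound 3, both lie a step beyond the scatter above it. For the measured compounds named here, the only measured single step, no change at the digits printed from compound 1 to compound 3 (within the scatter), exchanges one aryl group for another on the carbinol carbon and moves nothing; it does not touch the part of the molecule altered here.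

Compound 4 `OCC(O)Cn1nc2c(Br)c(Br)c(Br)c(Br)c2n1` differs from compound 2 as follows: 1,2-dihydroxyethyl in place of 2-hydroxypropyl on a saturated chain carbon bound to an aromatic nitrogen. Going by the values given here, no measured pair changes this side chain, so the expectation rests only on the spread of the three values. The compounds carrying a larger substituent at that carbon, compound 1 and compound 3, show the higher numbers, while compound 2 with its small chain stands lowest; compound 4 moves further from compound 2 rather than towards them, so the direction is uncertain. An expected step of a number 12 percentage points higher from compound 2 to compound 4 (beyond the scatter) in this assay is therefore judged modest, leaning towards a weaker effect. Compound 4 is estimated at 93%, within 72% to 112%.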

Compound 4, a percentage reported as activity, at one concentration (the size of the read-out at that concentration, not a potency): 89%
Estimate against measurement, compound 4: 4 percentage points above; measured number inside the range.
By their numbers in this assay, from the lowest: compounds 2 and 4 (each within the scatter of the next); then compounds 1 and 3 (each within the scatter of the next).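

In this assay, the exchange of 2-hydroxypropyl for 1,2-dihydroxyethyl on a saturated chain carbon bound to an aromatic nitrogen gives a number 8 percentage points higher from compound 2 to compound 4 (within the scatter). For the compounds shown here, this is the first measured change to this part of the side chain, and it shows that this exchange does not separate the two compounds at the concentration tested. No measurement shown here bears on this result, so the data offer no explanation for it.

From the compounds shown here alone, it remains open whether an amine or a carboxylic acid on this chain, or a longer chain, would give a step beyond the scatter. Going by these compounds, because the read-out comes from one concentration, it also remains open whether compound 2 and compound 4 would stay together at other concentrations.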